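This account rests on a few compounds, and the source may have more. Where it says the series, first, only, none or still open, it means among the compounds named here.

Compound 1 `C[N+](C)(CCCC(=O)[O-])CC1CC1` gives > 1000000 nM in an assay for inhibition of gamma-butyrobetaine dioxygenase (Homo sapiens), read by HPLC, with stated times of 15 min and 30 min (on this read-out higher numbers stand for weaker inhibition and lower numbers for stronger inhibition), which is a limit of the assay rather than a number.
Compound 2 `C[N+](C)(CCl)CCCC(=O)[O-]` gives 268000 nM in this assay.

Within the data shown here, compound 2 thus holds the only measured number in this assay; the other value shown is a limit. One step lies between the two measured compounds: an at least 3.7-fold lower number from compound 1 to compound 2 (0.57 log units; beyond the scatter). That step is at least modest, but only its floor is known. Its size rests on a limit: compound 1 sits at the limit of > 1000000 nM in this assay, at which 1 of the 2 values shown sits.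

Compound 3 `C[N+](C)(CBr)CCCC(=O)[O-]` has not yet been measured. It differs from compound 2 by bromo in place of chloro on a saturated chain carbon bound to an amine nitrogen. Among the measured compounds shown here, no measured step exchanges one halogen for another, and the single step that is known replaces a cyclopropyl by a chloro at the same position, so it does not match the change to compound 3 and gives no direction for it. Compound 3 is therefore expected to stay close to compound 2 in this assay. The step of a 1.3-fold lower number from compound 2 to compound 3 (0.13 log units; within the scatter) is expected to lie within the usual scatter. The estimate for compound 3 is 200000 nM, with a range from 70000 nM to 600000 nM.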

Compound 3, half-maximal inhibitory concentration: > 1000000 nM
Compound 3: only a limit was reported; the forecaster's own chance of this, stated with the estimate: 15%; middle value at least 5.0-fold (0.69 log units) away from the limit.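

At this position, on a saturated chain carbon bound to an amine nitrogen, the exchange of one halogen for another is not a silent change in this assay: bromo in place of chloro gives an at least 3.7-fold higher number from compound 2 to compound 3 (0.57 log units; beyond the scatter). The earlier step showed only that chloro stood apart from cyclopropyl, whereas this result shows that a halogen at this place is not enough to give a measured number, and among the three compounds only the chloromethyl group of compound 2 does so. Only the floor of the new step is known, and the step between compound 1 and compound 3 cannot be read, since both compounds sit at a limit: the limit of > 1000000 nM in this assay, at which 2 of the 3 values shown sit.

As far as these compounds go, how far compound 3 lies past its limit stays open, so the true size of the gap to compound 2 is unknown. Also open, from the compounds shown here alone, is whether fluoro, iodo or a hydroxyl group at this place, or a longer chain carrying the chloro, would give a measured number in this assay.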